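The source may report more compounds than this note shows. Statements on the series, on what has been measured and on what is new or still open speak of the compounds shown alone.

Three pyrazole-bearing compounds share a core and differ only in the groups at their ends. Compound 2 (`COc1ccc(-c2nn(-c3ccccc3)cc2C(=O)/C=C\Nc2ccc(F)cc2)cc1`) carries a fluoro group on the aniline ring, and in an ADME assay on HaCaT cells (Homo sapiens) for antiproliferative activity, read by MTT assay, with a stated time of 48 h (a higher number here means a weaker inhibitor, a lower number a stronger inhibitor), compound 2 gives 8910 nM. Compound 3 (`COc1ccc(-c2nn(-c3ccccc3)cc2C(=O)/C=C\Nc2ccc(Cl)cc2)cc1`) carries a chloro group in the same place, and compound 3 gives 20900 nM; this is the highest of the two numbers shown, the step being a 2.3-fold higher number from compound 2 to compound 3 (0.37 log units; beyond the scatter). Going by the values given here, compound 1 (`O=C(/C=C\Nc1ccc(C(F)(F)F)cc1)c1cn(-c2ccccc2)nc1-c1ccc(F)cc1`) has a trifluoromethyl group on the aniline ring but a fluorophenyl rather than a methoxyphenyl group elsewhere, so no single step links it to the others. In this assay compound 1 gives > 50000 nM, which is a limit of the assay and not a number.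

Compound 4 (`COc1ccc(-c2nn(-c3ccccc3)cc2C(=O)/C=C\Nc2ccc(C(F)(F)F)cc2)cc1`) is to be measured next. It differs from compound 3 by trifluoromethyl in place of chloro on an aromatic carbon. Among the compounds with values here, the one measured step that bears on this position, from compound 2 to compound 3, moved the number modestly upward as the halogen grew larger, and the only compound carrying trifluoromethyl sits at the limit. A further upward step, or a limit, is therefore expected for compound 4, estimated as a 1.7-fold higher number from compound 3 to compound 4 (0.22 log units; within the scatter). Compound 4 is expected at about 35000 nM, somewhere between 14000 nM and 90000 nM.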

Compound 4, half-maximal inhibitory concentration: > 50000 nM
Compound 4 was reported as a limit (the forecaster's own chance of this, stated with the estimate: 35%); at least 1.4-fold (0.15 log units) between middle value and limit.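

With the methoxyphenyl end held fixed, this position now carries three different groups. Replacing chloro with trifluoromethyl gives an at least 2.3-fold higher number from compound 3 to compound 4 (0.37 log units; beyond the scatter), and replacing fluoro with trifluoromethyl gives an at least 5.6-fold higher number from compound 2 to compound 4 (0.74 log units; beyond the scatter). Across these three compounds in this assay, the number therefore rises in the order fluoro, chloro, trifluoromethyl, with every step beyond the scatter, a sequence that the single step between the two halogens could not reveal. Compound 4 stands at a limit of the assay and not at a number, so both new steps give only a smallest size, and the step linking compound 1 to compound 4 cannot be read: the limit of > 50000 nM in this assay, at which 2 of the 4 values shown sit.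

The compounds shown leave open whether this rise continues as a general trend or merely reflects these three groups, and how far the number lies beyond the limit for trifluoromethyl. An amine, a carboxylic acid or a plain hydrogen at this position would test whether any group here can improve on compound 2, which gives 8910 nM.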